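Phenyl to 2-methoxyphenoxy a second time: compound 4 expected

This account rests on a few compounds, and the source may have more. Where it says the series, first, only, none or still open, it means among the compounds named here.

Measured so far in a physicochemical assay for solubility, with a stated time of 18 h, at pH 7.4; on this read-out lower numbers stand for lower solubility and higher numbers for higher solubility:
compound 1, `COc1ccccc1Oc1ccc2c(NCCCNCc3ccco3)ccnc2c1`, gives 14500 nM.
compound 2, `c1ccc(-c2ccc3c(NCCCNCc4ccco4)ccnc3c2)cc1`, gives 32000 nM.
compound 3, `COc1cccc(CNCCCNc2ccnc3cc(-c4ccccc4)ccc23)c1O`, gives 32000 nM.

Compound 2 and compound 3 stand level at the digits given, and the two of them carry the highest numbers of the three. They differ in the group on the chain carbon bound to the amine nitrogen: 2-hydroxy-3-methoxyphenyl in place of furan-2-yl on a saturated chain carbon bound to an amine nitrogen. That difference gives no change at the digits printed from compound 2 to compound 3 (within the scatter).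

Compound 1 differs from compound 2 on the aromatic carbon of the fused core: 2-methoxyphenoxy in place of phenyl on an aromatic carbon. This change produced a 2.2-fold lower number from compound 2 to compound 1 (0.34 log units; beyond the scatter), a modest but real step.

Compound 4, `COc1ccccc1Oc1ccc2c(NCCCNCc3cccc(OC)c3O)ccnc2c1`, has not yet been measured. Going by the values given here, it differs from compound 3 by 2-methoxyphenoxy in place of phenyl on an aromatic carbon, which is the same change, made in the same place, as the one that takes compound 2 to compound 1. Because that earlier change gave a 2.2-fold lower number from compound 2 to compound 1 (0.34 log units; beyond the scatter), a step of about the same size is expected here. Compound 4 is therefore expected to give 15000 nM, most likely between 7000 nM and 32000 nM, which amounts to an expected 2.1-fold lower number from compound 3 to compound 4 (0.33 log units; beyond the scatter).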

Compound 4, solubility: 14500 nM
Compound 4: the middle estimate sits 1.0-fold (0.01 log units) above what was measured; the range from low to high includes it.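

In this assay, 2-methoxyphenoxy in place of phenyl on the aromatic carbon gave a 2.2-fold lower number from compound 3 to compound 4 (0.34 log units; beyond the scatter), the same size at the digits printed as a 2.2-fold lower number from compound 2 to compound 1 (0.34 log units; beyond the scatter), so the step carried over intact from the furan-2-yl side chain to the 2-hydroxy-3-methoxyphenyl side chain. Going by these compounds alone, the side-chain swap agrees with this, giving no change at the digits printed from compound 1 to compound 4 (within the scatter) just as it gave no change at the digits printed from compound 2 to compound 3 (within the scatter), and in these four compounds the two changes therefore simply add, with no compound going against that reading. This is one repeat of the change across a single pair of side chains, so it does not show that the step would hold on other compounds of the series, and nothing available bears on why the step has this size.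

As far as these compounds go, whether the same step would appear with a longer chain, or with an amine or a carboxylic acid on the side chain, remains open. Also open, from the compounds shown here alone, is whether a smaller group such as methoxy, placed directly on the same aromatic carbon, would give a step of this size.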